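This account rests on a few compounds, and the source may have more. Where it says the series, first, only, none or still open, it means among the compounds named here.

Compound 1 `O=c1c2ccccc2c(-c2cccnc2)nn1CC1CCCCC1` stands highest of the three numbers in an assay on isolated protein (Oryctolagus cuniculus) with Thromboxane-A synthase (Homo sapiens) as the target, tested at 1 uM (a lower number here means less inhibition, a higher number more inhibition at the concentration tested (going by the name of the read-out)), giving 98%. Compound 3 `O=c1c2ccccc2c(-c2cccnc2)nn1CCSc1ncccn1` gives 86% in this assay, and compound 2 `COCCn1nc(-c2cccnc2)c2ccccc2c1=O` gives 55%. Two steps from compound 1 bear on the next change: a number 43 percentage points lower from compound 1 to compound 2 (beyond the scatter), methoxymethyl in place of cyclohexyl, and a number 12 percentage points lower from compound 1 to compound 3 (beyond the scatter), ((pyrimidin-2-yl)sulfanyl)methyl in place of cyclohexyl; between those two, a number 31 percentage points higher from compound 2 to compound 3 (beyond the scatter). Compound 4 `O=C(O)CCCn1nc(-c2cccnc2)c2ccccc2c1=O` differs from compound 1 by 2-carboxyethyl in place of cyclohexyl on a saturated chain carbon bound to an aromatic nitrogen. Both measured replacements of cyclohexyl at that carbon lowered the number, the open-chain one by the larger amount, so a drop is expected here too, of a size between the two: a number 33 percentage points lower from compound 1 to compound 4 (beyond the scatter). Compound 4 is therefore estimated at 65%, within 35% to 90%.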

Compound 4, a percentage reported as inhibition, at one concentration (the size of the read-out at that concentration, not a potency): 73%
For compound 4 the middle estimate is 8 percentage points below the measured one; measured number inside the range.
By their numbers in this assay, from the lowest: compound 2; then compound 4; then compound 3; then compound 1.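

In this assay the ring-free 2-carboxyethyl still gives a high number, though it does not match cyclohexyl (a number 25 percentage points lower from compound 1 to compound 4 (beyond the scatter)). At the chain end, carboxymethyl stands above methoxy (a number 18 percentage points higher from compound 2 to compound 4 (beyond the scatter)) and below (pyrimidin-2-yl)sulfanyl (a number 13 percentage points lower from compound 3 to compound 4 (beyond the scatter)), so among compounds 2, 3 and 4 the number depends on the end group, and an open chain does not fix it. No available measurement explains these steps.

Still open, as far as these compounds go, is whether the free acid itself matters. A methyl ester or a primary amine at the chain end, or a longer chain carrying the carboxylic acid, would separate the end group from chain length.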